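The compounds below may be only part of what the source reports. "The series", "measured", "known", "first", "only" and "open" are said of these compounds alone.

Measured in an ADME assay on HaCaT cells (Homo sapiens) for cytotoxicity, read by MTT assay, with a stated time of 48 h; on this read-out lower numbers stand for stronger inhibition and higher numbers for weaker inhibition:
Compound 1 `Clc1ccc2[nH]c(-c3cn(-c4ccccc4)nc3-c3ccccc3)nc2c1`: > 50000 nM
Compound 2 `Clc1ccc(-c2nn(-c3ccccc3)cc2-c2nc3ccccc3[nH]2)cc1`: > 50000 nM

Neither entry is a number. Compound 2 gives > 50000 nM, and this is a limit of the assay. Compound 1 gives > 50000 nM, which is also a limit. For the measured compounds named here, the series so far therefore sits entirely at one end of the scale: the limit of > 50000 nM in this assay, at which 2 of the 2 values shown sit. Going by the values given here, no measured step is available to size a substitution in this assay.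

The next compound is compound 3 `Clc1ccc(-c2nn(-c3ccccc3)cc2-c2nc3cc(Cl)ccc3[nH]2)cc1`. Relative to compound 2 it has chloro in place of hydrogen on an aromatic carbon, on the six-membered ring of carbon only that is part of the fused system of two rings: chloro in place of hydrogen on an aromatic carbon.

The expectation rests on compound 1, which already carries a chloro on a fused system of two rings and stands at > 50000 nM, a limit. The expected step of a number no higher from compound 2 to compound 3 (the limit leaves the size open) is none beyond the scatter, and any shift that does appear is expected towards lower numbers. A further limit is the likeliest report. For compound 3 the estimate is 50000 nM, with an expected range of 15000 nM to 100000 nM.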

Compound 3, half-maximal inhibitory concentration: > 50000 nM
Compound 3: a limit, no number (the forecaster's own chance of this, stated with the estimate: 65%); the middle value lies on the limit itself.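

Compound 1, compound 2 and compound 3 all report limits rather than numbers in this assay, so no step among them can be read, and the whole set stays at one end of the scale: the limit of > 50000 nM in this assay, at which 3 of the 3 values shown sit.

The compounds shown leave open whether any change on the shared core would give a readable number in this assay.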